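Chloro in Place of Hydrogen on a Fused Aromatic Ring

A few compounds are considered here, and "the series" means these few. Any claim that something is new, unique, unknown or untested is made for them only; others in the source may bear on it.

Two compounds sharing a bicyclic core carrying an imidazoline-bearing side chain have been examined in an assay on isolated protein for binding affinity to Adrenergic receptor alpha-1 (Rattus norvegicus), read by radioligand binding, in the presence of a further agent that is not named here; a higher number here means a weaker inhibitor, a lower number a stronger inhibitor. Compound 1, `COc1cccc2c1C=C(CC1CN=CN1)CC2`, gives 158 nM. Compound 2, `C1=NCC(CC2CCc3ccccc3C2)N1`, the unsubstituted parent, gives 794 nM, the higher of the two numbers and the weaker binder by a margin that lies beyond the usual scatter. Compound 3, `Clc1cccc2c1CC(CC1CN=CN1)CC2`, has not yet been measured. It differs from compound 2 in a single place: chloro in place of hydrogen on an aromatic carbon, the substituent sitting on an aromatic carbon of the six-membered aromatic ring of carbon only, part of a fused system of two rings. Within the data shown here, no directly comparable pair of measured compounds exists, so the size of this step is open. Compound 1 carries a substituent on the same ring and gives the stronger number, but it also differs elsewhere, so that comparison is only suggestive. A modest gain in affinity is expected, with a step of a 2.5-fold lower number from compound 2 to compound 3 (0.39 log units; beyond the scatter) in this assay. Compound 3 is expected to give 320 nM, within a range from 100 nM to 1000 nM.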

Compound 3, inhibition constant: 316 nM
Compound 3: the middle estimate sits 1.0-fold (0.01 log units) above what was measured, and the stated range covers the measured number.
By their numbers in this assay, from the lowest: compounds 1 and 3 (each within the scatter of the next); then compound 2.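

In this assay, among these compounds, chloro in place of hydrogen on an aromatic carbon, ortho to a fused ring and meta to a fused ring, brings a 2.5-fold lower number from compound 2 to compound 3 (0.40 log units; beyond the scatter), a modest step and the first direct reading of a change on this aromatic ring. Among the compounds shown here, a single chlorine atom is thus enough to move the number beyond the usual scatter, something no earlier pair differing in one place could show. Nothing measured here accounts for the step, so its cause remains unexplained.

Whether the gain is specific to chloro remains open, as the compounds shown do not tell how fluoro, methyl or an amine on this same carbon would compare. They also do not show whether chloro on another carbon of this aromatic ring would give a step of similar size.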